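Methoxyphenyl position shift in the octylsulfonamide benzoic acid series

The source may hold more compounds than are shown below. What is called first, only, known or untested is meant among the compounds shown, and "the series" means these compounds.

Among the compounds with values here, compound 3 `CCCCCCCCS(=O)(=O)Nc1ccc(-c2ccccc2OC)cc1C(=O)O` gives 27600 nM in an assay on mitochondria (strain BALB/c) for inhibition of glycerol-3-phosphate acyltransferase 1, mitochondrial (Mus musculus), read by scintillation counting, with a stated time of 10 min (a lower number here means a stronger inhibitor, a higher number a weaker inhibitor), and carries the highest number of the three measured so far. Compound 1 `CCCCCCCCS(=O)(=O)Nc1ccc(-c2ccccc2Cl)cc1C(=O)O` gives 14400 nM in this assay and compound 2 `CCCCCCCCS(=O)(=O)Nc1ccc(-c2ccc(Cl)cc2)cc1C(=O)O` gives 9200 nM in this assay. The two steps that reach compound 3 are a 1.9-fold higher number from compound 1 to compound 3 (0.28 log units; within the scatter) and a 3.0-fold higher number from compound 2 to compound 3 (0.48 log units; beyond the scatter).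

Compound 4 `CCCCCCCCS(=O)(=O)Nc1ccc(-c2ccc(OC)cc2)cc1C(=O)O` is not yet measured. It differs from compound 3 by 4-methoxyphenyl in place of 2-methoxyphenyl on an aromatic carbon. Within the data shown here, the only measured step that bears on this move is the matching chloro pair: a 1.6-fold lower number from compound 1 to compound 2 (0.19 log units; within the scatter). That step stayed inside the scatter, so no more than a comparable shift is expected here. The expected step is a 1.6-fold lower number from compound 3 to compound 4 (0.21 log units; within the scatter), a lower number in this assay that should not clearly pass beyond the scatter. Compound 4 is therefore estimated at 17000 nM in this assay, with a range from 7000 nM to 45000 nM.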

Compound 4, half-maximal inhibitory concentration: 19500 nM
Compound 4: the middle estimate sits 1.1-fold (0.06 log units) below what was measured; the measured number falls inside the stated range.
By their numbers in this assay, from the lowest: compounds 2, 1, 4 and 3 (each within the scatter of the next, the first and the last beyond it).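

In this assay, the shift from 2-methoxyphenyl to 4-methoxyphenyl gives a 1.4-fold lower number from compound 3 to compound 4 (0.15 log units; within the scatter), so with methoxy, as with chloro, this position shift is not resolved. The step that exchanges 2-chlorophenyl for 4-methoxyphenyl, a 1.4-fold higher number from compound 1 to compound 4 (0.13 log units; within the scatter), also stays within the scatter, so changing the group and its position together is not resolved either. Compound 4 adds a second step of methoxy in place of chloro, a 2.1-fold higher number from compound 2 to compound 4 (0.33 log units; beyond the scatter), and the change reads alike on the two cores: the same change on two cores in this assay, a 1.9-fold higher number (0.28 log units; within the scatter) from compound 1 to compound 3 and a 2.1-fold higher number (0.33 log units; beyond the scatter) from compound 2 to compound 4, 1.1-fold (0.04 log units) apart, within the scatter of two such steps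

With only chloro and methoxy on this ring, the compounds shown leave open whether an amine, a nitrile or a carboxylic acid there would move the number clearly beyond the scatter. As far as these compounds go, how a shorter chain in place of the octyl chain would read on this core also remains open.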